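From 4-fluorobenzyl to 4-methoxybenzyl: working notes

The source may report more compounds than this note shows. Statements on the series, on what has been measured and on what is new or still open speak of the compounds shown alone.

In an ADME assay on HEK293 cells (Homo sapiens) for cytotoxicity, read by MTT assay, with a stated time of 24 h (on this read-out higher numbers stand for weaker inhibition and lower numbers for stronger inhibition), compound 3 `CN(C)CCCNc1nc2cc([N+](=O)[O-])ccc2nc1NCc1ccc(F)cc1` gives 4.28 ug/mL. In the same read-out, compound 1 `CN(C)CCCNc1nc2cc([N+](=O)[O-])ccc2nc1NCc1ccc(C(F)(F)F)cc1` gives 5.66 ug/mL and compound 2 `CN(C)CCCNc1nc2cc([N+](=O)[O-])ccc2nc1NCc1ccc(Cl)cc1` gives 10.7 ug/mL. Compound 3 cannot be separated from compound 1, the measured step being a 1.3-fold lower number from compound 1 to compound 3 (0.12 log units; within the scatter). It does stand apart from compound 2, the measured step being a 2.5-fold lower number from compound 2 to compound 3 (0.40 log units; beyond the scatter).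

The next compound is compound 4 `COc1ccc(CNc2nc3ccc([N+](=O)[O-])cc3nc2NCCCN(C)C)cc1`, with methoxy in place of fluoro on an aromatic carbon. The group sits para to a large group, the place where all three measured exchanges occur. The third of these exchanges is a 1.9-fold higher number from compound 1 to compound 2 (0.28 log units; within the scatter). Among the compounds with values here, only the step to compound 3 from compound 2 passes the scatter, and it is modest. None of the three compounds carries methoxy, so these steps offer only an indirect guide to its effect. Within the data shown here, with exchanges at this place so far moving the number little, a large step is not expected. The expected change in this assay is a 1.5-fold higher number from compound 3 to compound 4 (0.18 log units; within the scatter), which stays within the scatter. The estimate for compound 4 is 6.5 ug/mL, with an expected range of 3 ug/mL to 14 ug/mL.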

Compound 4, half-maximal inhibitory concentration: 38.6 ug/mL
Estimate against measurement, compound 4: 5.9-fold (0.77 log units) below, outside the stated range (above it).
By their numbers in this assay, from the lowest: compounds 3, 1 and 2 (each within the scatter of the next, the first and the last beyond it); then compound 4.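

Notes on the result: in this assay, methoxy is the first group at this place to separate clearly from all the others, with a 9.0-fold higher number from compound 3 to compound 4 (0.96 log units; beyond the scatter), a 6.8-fold higher number from compound 1 to compound 4 (0.83 log units; beyond the scatter) and a 3.6-fold higher number from compound 2 to compound 4 (0.56 log units; beyond the scatter). The position is therefore more sensitive than fluoro, chloro and trifluoromethyl alone suggested, as the widest gap among those three was a 2.5-fold lower number from compound 2 to compound 3 (0.40 log units; beyond the scatter). Compound 4 gives the weakest inhibition of the four compounds, so the exchange of fluoro for methoxy, which adds only one heavy atom and one hydrogen-bond acceptor, is enough to produce the largest step in the series, though nothing available explains this step.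

Still open, going by these compounds, is whether this step is specific to methoxy: a hydroxyl, an ethoxy or a dimethylamino group at the same place could fall with compound 4 or with compounds 1, 2 and 3. It is also unclear whether the step would persist with a carboxylic acid or an amine in place of the nitro group on the shared core, since all four compounds carry that nitro group and the same side chain.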